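Heteroaryl Amide Swap on a Cytotoxicity Series

The compounds below may be only part of what the source reports. "The series", "measured", "known", "first", "only" and "open" are said of these compounds alone.

Three analogues sharing one core have been tested in a functional assay on A375P cells (Homo sapiens) for cytotoxicity, read by MTT assay, with a stated time of 24 h; a lower number here means a stronger inhibitor, a higher number a weaker inhibitor. Compound 1 `CNc1ncnc2c(CNc3cc(NC(=O)c4cc(C(F)(F)F)cc(C(F)(F)F)c4)ccc3C)cccc12` gives 769 nM, compound 2 `CNc1ncnc2c(CNc3cc(NC(=O)c4ccc(Cl)c(C(F)(F)F)c4)ccc3C)cccc12` gives 9700 nM, and compound 3 `CNc1ncnc2c(CNc3cc(NC(=O)c4ccnnc4)ccc3C)cccc12` gives 61700 nM, the highest of the three numbers. The nearest measured step is a 6.4-fold higher number from compound 2 to compound 3 (0.80 log units; beyond the scatter). Compound 4 `CNc1ncnc2c(CNc3cc(NC(=O)c4cc(C)on4)ccc3C)cccc12` differs from compound 3 by 5-methyl-1,2-oxazol-3-yl in place of pyridazin-4-yl on a carbonyl carbon. Among the compounds with values here, no measured step exchanges one heteroaromatic ring for another; the only step that bears on this position replaced a substituted phenyl with a heteroaromatic ring, and here both rings are heteroaromatic with two hetero atoms. Compound 4 is therefore expected to show a 1.4-fold lower number from compound 3 to compound 4 (0.14 log units; within the scatter), a step not expected to exceed the scatter. The estimate for compound 4 in this assay is 45000 nM, with a range from 12000 nM to 160000 nM.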

Compound 4, half-maximal inhibitory concentration: 1200 nM
Estimate against measurement, compound 4: 38-fold (1.57 log units) above, outside the stated range (below it).
By their numbers in this assay, from the lowest: compounds 1 and 4 (each within the scatter of the next); then compound 2; then compound 3.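

In this assay the position on the carbonyl carbon proves highly sensitive to which heteroaromatic ring it carries, with the exchange giving a 51-fold lower number from compound 3 to compound 4 (1.71 log units; beyond the scatter). A heteroaromatic ring here need not be the weakest choice, as replacing the substituted phenyl gives an 8.1-fold lower number from compound 2 to compound 4 (0.91 log units; beyond the scatter), and compound 4 lies within the scatter of compound 1. No available evidence accounts for this difference between two rings with equal hetero atom and acceptor counts. On these data alone, whether the methyl of the 5-methyl-1,2-oxazol-3-yl group contributes remains open, as does the effect of an amine or a carboxylic acid in its place.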